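The compounds below may be only part of what the source reports. "The series", "measured", "known", "first", "only" and "open" are said of these compounds alone.

Compound 2 `CCSc1ccc(C2CC(=O)N2c2cc(OC)c(OC)c(OC)c2)cc1` gives 141 nM in a functional assay on MCF7 cells (Homo sapiens) for inhibition, read by resazurin assay, with a stated time of 72 h; on this read-out lower numbers stand for stronger inhibition and higher numbers for weaker inhibition. Compound 1 `CCSc1ccc(C2C(Oc3ccccc3)C(=O)N2c2cc(OC)c(OC)c(OC)c2)cc1` gives 210 nM in this assay.

Going by the values given here, compound 2 holds the lowest of the two numbers, with compound 1 nearest; the only measured step, a 1.5-fold lower number from compound 1 to compound 2 (0.17 log units; within the scatter), lies within the scatter. Compound 3 `CCOc1ccc(C2CC(=O)N2c2cc(OC)c(OC)c(OC)c2)cc1` carries ethoxy in place of ethylsulfanyl on an aromatic carbon. Among the compounds with values here, that step concerned a saturated ring carbon and does not bear on this change at the aromatic carbon, so no measured step guides the direction. Compound 3 is therefore expected to remain close to compound 2, with an estimated 250 nM and a range from 90 nM to 700 nM. This corresponds to an expected 1.8-fold higher number from compound 2 to compound 3 (0.25 log units; within the scatter), a step not beyond the scatter.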

Compound 3, half-maximal inhibitory concentration: 64 nM
Compound 3: the middle estimate sits 3.9-fold (0.59 log units) above what was measured; the measured number lies below the stated range.
By their numbers in this assay, from the lowest: compound 3; then compounds 2 and 1 (each within the scatter of the next).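

In this assay, ethoxy in place of ethylsulfanyl on an aromatic carbon, para to a large group, gives a 2.2-fold lower number from compound 2 to compound 3 (0.34 log units; beyond the scatter) and so shows a modest step beyond the scatter. This position therefore responds to an exchange of sulfur for oxygen between two groups of equal heavy-atom count, whereas the earlier step at the saturated ring carbon stayed within the scatter. No supporting data explain this difference.

From the compounds shown here alone, whether a longer chain such as propoxy, or an amine, at this aromatic carbon would give a lower or higher number remains open. So does whether phenoxy on the saturated ring carbon would have the same effect alongside ethoxy.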